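The compounds below may be only part of what the source reports. "The series", "measured", "known", "first", "only" and "open" are said of these compounds alone.

In a functional assay on the whole organism for inhibition, with Scenedesmus acutus as the target (on this read-out lower numbers stand for stronger inhibition and higher numbers for weaker inhibition), compound 1 `CCOC(=O)c1cc(N2C(=O)C3=C(CCCC3)C2=O)c(F)cc1Cl` gives 57.5 nM and compound 2 `CCC(C)OC(=O)c1cc(N2C(=O)C3=C(CCCC3)C2=O)c(F)cc1Cl` gives 60.3 nM, so the two stand level. Compound 3 `C#CCOc1cc(N2C(=O)C3=C(CCCC3)C2=O)c(F)cc1Cl` has propargyloxy in place of sec-butoxycarbonyl on an aromatic carbon, ortho to a chloro group and para to a fluoro group: propargyloxy in place of sec-butoxycarbonyl on an aromatic carbon. For the measured compounds named here, the only measured step, a 1.0-fold higher number from compound 1 to compound 2 (0.02 log units; within the scatter), lies within the scatter, but it alters only the chain end and never removes the whole group, so it offers weak guidance. A tentative, modest move towards stronger inhibition is expected, with an estimated step of a 2.0-fold lower number from compound 2 to compound 3 (0.30 log units; within the scatter). For compound 3 the estimated value is 30 nM, with an expected range from 8 nM to 120 nM.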

Compound 3, half-maximal inhibitory concentration: 15.9 nM
Compound 3: middle estimate off by 1.9-fold (0.28 log units), on the high side, and the stated range covers the measured number.
By their numbers in this assay, from the lowest: compound 3; then compounds 1 and 2 (each within the scatter of the next).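

Altering only the chain end of the ester left the number level, but exchanging the whole group on this aromatic carbon does move it. Propargyloxy in place of sec-butoxycarbonyl gives a 3.8-fold lower number from compound 2 to compound 3 (0.58 log units; beyond the scatter), and propargyloxy in place of ethoxycarbonyl gives a 3.6-fold lower number from compound 1 to compound 3 (0.56 log units; beyond the scatter), so here the group with fewer heavy atoms goes with stronger inhibition than either ester. Nothing available explains this shift. Going by these compounds, whether a propoxy chain, which has no triple bond, or a carboxylic acid on this carbon would keep that inhibition remains open.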